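The source may report more compounds than this note shows. Statements on the series, on what has been measured and on what is new or still open speak of the compounds shown alone.

Values in a physicochemical assay for solubility, in phosphate buffer, with a stated time of 18 h (a lower number here means a less soluble compound, a higher number a more soluble compound), for the measured compounds

Compound 1 `N#Cc1c(N)nc2nc(C3CC3)ncc2c1N` gives 23000 nM
Compound 2 `N#Cc1c(N)nc2nc(C3CCC3)ncc2c1N` gives 217000 nM
Compound 3 `Cc1nc(C(C)(C)C)nc2nc(N)c(C#N)c(N)c12` gives 37000 nM

Compound 3 stands within the scatter of compound 1 and clearly under compound 2, the highest of the three. The next step leads to compound 4 `CC(C)(C)c1nc(-c2ccccc2)c2c(N)c(C#N)c(N)nc2n1` and is phenyl in place of methyl on an aromatic carbon. Among the compounds with values here, only one measured step bears on it, and only loosely. That step is a 9.4-fold higher number from compound 1 to compound 2 (0.97 log units; beyond the scatter) and it puts cyclobutyl in place of cyclopropyl on an aromatic carbon. Within the data shown here, it went upward, but it concerns other groups in another place, and no measured step brings in an aromatic ring, so the direction here is an expectation without direct support. A lower number is expected in this assay by a step of about the size of a 9.4-fold higher number from compound 1 to compound 2 (0.97 log units; beyond the scatter) and beyond the scatter. The estimated change is a 5.3-fold lower number from compound 3 to compound 4 (0.72 log units; beyond the scatter) on this reading. For compound 4 the estimated value is 7000 nM with an expected range from 1500 nM to 25000 nM in this account.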

Compound 4, solubility: 4000 nM
Compound 4: middle estimate off by 1.8-fold (0.24 log units), on the high side; the measured number falls inside the stated range.
By their numbers in this assay, from the lowest: compound 4; then compounds 1 and 3 (each within the scatter of the next); then compound 2.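

In this assay, the carbon that carries methyl in compound 3 proves sensitive to substitution: phenyl in place of methyl gives a 9.3-fold lower number from compound 3 to compound 4 (0.97 log units; beyond the scatter). Within the data shown here, this is the first measured change at this position and the first to bring in an aromatic ring of carbon only. Among these compounds, it also runs in the opposite direction to the only earlier step, a 9.4-fold higher number from compound 1 to compound 2 (0.97 log units; beyond the scatter), which involved other groups in another place. Nothing measured here explains the drop.

From the compounds shown here alone, a single step cannot separate the presence of an aromatic ring from the larger group as such, so it remains open whether a pyridyl ring, an amine or a longer alkyl chain at this carbon would track phenyl or methyl. Going by these compounds, it is also open whether the same change would run the same way with cyclobutyl in place of the tert-butyl group.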